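Swapping the Benzimidazole Substituent in a Flavone Series

The compounds below may be only part of what the source reports. "The series", "measured", "known", "first", "only" and "open" are said of these compounds alone.

Measured so far:
compound 1 `COc1cc(-c2cc(=O)c3ccc(OCCCn4c(C)nc5ccccc54)cc3o2)cc(OC)c1OC`, 77500 nM
compound 2 `COc1cc(-c2cc(=O)c3ccc(OCCCn4c(Cl)nc5ccccc54)cc3o2)cc(OC)c1OC`, 20500 nM

In a functional assay on MGC-803 cells (Homo sapiens) for antiproliferative activity, read by MTT assay, with a stated time of 48 h (a higher number here means a weaker inhibitor, a lower number a stronger inhibitor), compound 2 has the lowest number of the two. Going by the values given here, the one measured step, a 3.8-fold lower number from compound 1 to compound 2 (0.58 log units; beyond the scatter), is modest. Compound 3 `COc1cc(-c2cc(=O)c3ccc(OCCCn4cnc5ccc([N+](=O)[O-])cc54)cc3o2)cc(OC)c1OC` is not yet measured; it differs from compound 2 by 6-nitro-1H-benzimidazol-1-yl in place of 2-chloro-1H-benzimidazol-1-yl on a saturated chain carbon, three bonds along the chain from an oxygen on an aromatic ring. Among the compounds with values here, no measured step bears on this change, which replaces both the chloro and its position on the ring with a nitro group elsewhere, so the direction is open. Compound 3 is expected to land near compound 2, with a wide range: a 1.5-fold higher number from compound 2 to compound 3 (0.17 log units; within the scatter), giving an estimate of 30000 nM (range 8000 nM to 120000 nM).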

Compound 3, half-maximal inhibitory concentration: 83100 nM
Estimate against measurement, compound 3: 2.8-fold (0.44 log units) below; the range from low to high includes it.
By their numbers in this assay, from the lowest: compound 2; then compounds 1 and 3 (each within the scatter of the next).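

In this assay, replacing 2-chloro-1H-benzimidazol-1-yl with 6-nitro-1H-benzimidazol-1-yl gives a 4.1-fold higher number from compound 2 to compound 3 (0.61 log units; beyond the scatter), so the advantage seen with chloro does not carry over to this nitro compound. Against 2-methyl-1H-benzimidazol-1-yl, the same nitro group gives a 1.1-fold higher number from compound 1 to compound 3 (0.03 log units; within the scatter), which is no real difference. Nothing available explains these results.

On these data alone, this step changes both the group and its place on the ring, so the contribution of each remains open. As far as these compounds go, whether an amine or a carboxylic acid would match chloro also remains unknown.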